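The source may hold more compounds than are shown below. What is called first, only, known or untested is meant among the compounds shown, and "the series" means these compounds.

Within the data shown here, compound 1 `O=C(NO)[C@@H]1CSCN1S(=O)(=O)c1ccc(-c2ccccc2)cc1` is the only member of the set with a single measured number. In an assay on isolated protein for inhibition of matrix metalloproteinase-9 (Homo sapiens), read by fluorescence, with stated times of 1 h and 30 min (on this read-out lower numbers stand for stronger inhibition and higher numbers for weaker inhibition), compound 1 gives 230 nM. Compound 2 `NC(=O)[C@H]1CCC(=O)N1Cc1ccc(-c2ccccc2)cc1` has "not determined" (no result reported) in this assay, so no result is reported for it. For compound 3 `O=C(NO)[C@H]1CCC(=O)N1Cc1ccccc1Cl` this assay reports only a limit, > 500000 nM, which is the limit of > 500000 nM in this assay, at which 1 of the 3 values shown sits. Compound 4 `COc1ccc(Oc2ccc(S(=O)(=O)N3CSC[C@H]3C(=O)NO)cc2)cc1` differs from compound 1 by 4-methoxyphenoxy in place of phenyl on an aromatic carbon, on an aromatic carbon para to a large group. Among the measured compounds shown here, no pair of measured compounds differs in one place, so the size of this step cannot be read from the measured data. The expected step is a 23-fold lower number from compound 1 to compound 4 (1.36 log units; beyond the scatter), a move to stronger inhibition beyond the usual scatter. Compound 4 is estimated at 10 nM in this assay, with a range from 2 nM to 60 nM.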

Compound 4, half-maximal inhibitory concentration: 2 nM
For compound 4 the middle estimate is 5.0-fold (0.70 log units) above the measured one; measured number inside the range.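

Among these compounds, replacing phenyl with 4-methoxyphenoxy on an aromatic carbon para to a large group gives a 120-fold lower number from compound 1 to compound 4 (2.06 log units; beyond the scatter) in this assay, the first step that can be read. This position therefore accepts the larger group, and the change moves the series to stronger inhibition. Nothing measured here accounts for the size of this step.

The entering group differs from phenyl in both its oxygen link and its methoxy group, so the share of each remains unresolved. From the compounds shown here alone, whether an unsubstituted phenoxy or a benzyloxy group at this position would keep the gain remains open.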